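Chloro for fluoro on the benzyl: microsomal stability

A few compounds are considered here, and "the series" means these few. Any claim that something is new, unique, unknown or untested is made for them only; others in the source may bear on it.

Working notes on compound 1 `CS(=O)(=O)Nc1ccc2c(c1)S(=O)(=O)N=C(C1=C(O)C3CCCC3N(Cc3ccc(F)cn3)C1=O)N2`, compound 2 `CS(=O)(=O)Nc1ccc2c(c1)S(=O)(=O)N=C(C1=C(O)[C@H]3CCC[C@H]3N(Cc3ccc(F)c(F)c3)C1=O)N2` and compound 3 `CC(C)(C)CCN1C(=O)C(C2=NS(=O)(=O)c3cc(NS(C)(=O)=O)ccc3N2)=C(O)C2CCCCC21`, all tested in an in vitro ADME assay on microsomes from liver (Homo sapiens) for metabolic stability; a higher number here means that the compound lasts longer, a lower number that the compound disappears faster. Compound 1 reaches the limit of the assay, reported as > 1 h. Compound 2 likewise returns only a limit, > 1 h, so its true half-life is not resolved. Compound 3 gives 0.267 h in this assay. Compound 2 therefore stands at the limit of > 1 h in this assay, at which 2 of the 3 values shown sit. Compound 4 `CS(=O)(=O)Nc1ccc2c(c1)S(=O)(=O)N=C(C1=C(O)[C@H]3CCC[C@H]3N(Cc3ccc(F)c(Cl)c3)C1=O)N2` is not yet measured; it differs from compound 2 by chloro in place of fluoro on an aromatic carbon. Within the data shown here, no step between measured compounds is available for comparison. The step from compound 2 to compound 4 is expected to be small, about a step that the limit leaves unreadable from compound 2 to compound 4. Compound 4 is thus estimated at 1.5 h, with a range from 0.6 h to 4 h, and a fair chance that only a limit is reported again.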

Compound 4, half-life: > 1 h
Compound 4 was reported as a limit (the forecaster's own chance of this, stated with the estimate: 65%); the middle value is on the limit's open side.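

Compound 2 and compound 4 both return only a limit in this assay, so chloro in place of fluoro gives no readable step. The compounds shown leave open how far either true half-life lies past that limit, and whether the two differ at all.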